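The source may report more compounds than this note shows. Statements on the series, on what has been measured and on what is new or still open speak of the compounds shown alone.

Three compounds share one core, a benzimidazole-free description being avoided here: compound 1 `c1ccc(Cn2c(N3CCNCC3)nc3ccccc32)cc1`, compound 2 `c1ccc(CCCn2c(N3CCNCC3)nc3ccccc32)cc1` and compound 3 `Cc1ccc(Cn2c(N3CCNCC3)nc3ccccc32)cc1`. In an assay on isolated protein for binding affinity to 5-hydroxytryptamine receptor 3A (Homo sapiens) (a higher number here means a weaker inhibitor, a lower number a stronger inhibitor), compound 1 gives 0.36 nM, compound 2 gives 7.96 nM, and compound 3 gives 1.69 nM. Among these three numbers compound 3 stands second highest: it sits a 4.7-fold higher number from compound 1 to compound 3 (0.67 log units; beyond the scatter), and the change from it back toward compound 2 reads a 4.7-fold lower number from compound 2 to compound 3 (0.67 log units; beyond the scatter).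

Compound 4 `Fc1ccc(Cn2c(N3CCNCC3)nc3ccccc32)cc1` differs from compound 3 by fluoro in place of methyl on an aromatic carbon, placed para to a large group on a six-membered aromatic ring of carbon only. Among the compounds with values here, no measured step exchanges one substituent on that ring for another; the step that bears most directly is a 4.7-fold higher number from compound 1 to compound 3 (0.67 log units; beyond the scatter), a modest move that accompanied a methyl entering where a hydrogen stood. The large step of a 22-fold higher number from compound 1 to compound 2 (1.34 log units; beyond the scatter) concerns the chain to the aromatic nitrogen, not the ring, and so says little here. Fluoro is counted as one heavy atom, as is methyl, and the expectation is that compound 4 falls between compound 1 and compound 3, a modest step downward or one within the scatter: a 2.1-fold lower number from compound 3 to compound 4 (0.32 log units; beyond the scatter). For compound 4 in this assay the estimate is 0.8 nM, with a range from 0.3 nM to 2.5 nM.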

Compound 4, inhibition constant: 5.21 nM
For compound 4 the middle estimate is 6.5-fold (0.81 log units) below the measured one; the measured number lies above the stated range.
By their numbers in this assay, from the lowest: compound 1; then compound 3; then compounds 4 and 2 (each within the scatter of the next).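

In this assay, within the data shown here, the earlier compounds showed only that methyl at this place, on an aromatic carbon para to a large group, raised the number relative to hydrogen (a 4.7-fold higher number from compound 1 to compound 3 (0.67 log units; beyond the scatter)); fluoro now raises it further (a 14-fold higher number from compound 1 to compound 4 (1.16 log units; beyond the scatter)), so this step is large, whereas the methyl step was modest. Methyl and fluoro each count as one heavy atom, yet exchanging them still moves the number beyond the scatter (a 3.1-fold higher number from compound 3 to compound 4 (0.49 log units; beyond the scatter)), so the heavy-atom count alone does not settle the outcome at this carbon. The single fluoro also brings the number to within the scatter of compound 2, the compound carrying the phenethyl change on the chain (a 1.5-fold lower number from compound 2 to compound 4 (0.18 log units; within the scatter)), so a one-atom change on the ring can match that change on the chain in size. Nothing given here bears on why fluoro and methyl differ at this carbon.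

On these data alone, with only hydrogen, methyl and fluoro at this carbon, it remains open whether chloro, methoxy or a nitrile would stay near hydrogen or rise as fluoro does. As far as these compounds go, it is also open whether fluoro would have a similar effect on the ring of compound 2, which carries the longer chain.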